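This account rests on a few compounds, and the source may have more. Where it says the series, first, only, none or still open, it means among the compounds named here.

Among the compounds with values here, the series shares one amide-linked core, and in a functional assay on HepG2 cells (Homo sapiens) for cytotoxicity, read by MTT assay, with a stated time of 72 h (on this read-out lower numbers stand for stronger inhibition and higher numbers for weaker inhibition), the three measured members are spread out. Compound 1, `O=C(Nc1ccc(Oc2ccnc3[nH]ccc23)cc1)c1nn(-c2ccc(Cl)cc2)ccc1=O`, gives 19500 nM in this assay. Compound 2, `COc1ccc(-n2ccc(=O)c(C(=O)Nc3ccc(Oc4ccnc5[nH]ccc45)cc3)n2)cc1`, gives 50800 nM in this assay, which is a 2.6-fold higher number from compound 1 to compound 2 (0.42 log units; beyond the scatter). Compound 3, `Cn1ccc2c(Oc3ccc(NC(=O)c4nn(-c5ccc(Cl)cc5)ccc4=O)cc3)ccnc21`, is reported in this assay only as a limit, > 60000 nM, and not as a number. Set against compound 1 that reads as an at least 3.0-fold higher number from compound 1 to compound 3 (0.48 log units; beyond the scatter), so compound 3 sits at the limit of > 60000 nM in this assay, at which 1 of the 3 values shown sits.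

Compound 4, `Cn1ccc2c(Oc3ccc(NC(=O)c4nn(-c5ccc(Br)cc5)ccc4=O)cc3)ccnc21`, differs from compound 3 in one place: bromo in place of chloro on an aromatic carbon. Within the data shown here, no measured step exchanges one halogen for another; the two steps that are known, a 2.6-fold higher number from compound 1 to compound 2 (0.42 log units; beyond the scatter) and an at least 3.0-fold higher number from compound 1 to compound 3 (0.48 log units; beyond the scatter), both moved the numbers upward and both were modest. The exchange of chloro for bromo is a smaller alteration than either of those, so for compound 4 the expectation in this assay is a step that the limit leaves unreadable from compound 3 to compound 4, that is, no step beyond the scatter from where compound 3 already stands. Compound 4 is therefore estimated at 70000 nM in this assay, with a range from 30000 nM to 160000 nM, and it is expected that the measurement will most likely again come back as a limit rather than as a number.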

Compound 4, half-maximal inhibitory concentration: 39200 nM
Estimate against measurement, compound 4: 1.8-fold (0.25 log units) above, and the stated range covers the measured number.
By their numbers in this assay, from the lowest: compounds 1, 4 and 2 (each within the scatter of the next, the first and the last beyond it). At a limit, above all of these: compound 3.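

In this assay, the exchange of chloro for bromo on the aromatic carbon para to a large group, 4-chlorophenyl to 4-bromophenyl, gives an at least 1.5-fold lower number from compound 3 to compound 4 (0.18 log units; that floor lies within the scatter), the first listed step in this series that runs toward a lower number rather than a higher one. With the methyl kept on the aromatic nitrogen, compound 4 brings this methylated core into the measurable range at 39200 nM, so a single halogen exchange at this position is enough to yield a measured number. Since that floor lies within the scatter, the size of the step can't be stated, and it stays a floor because compound 3 is recorded only as a limit: the limit of > 60000 nM in this assay, at which 1 of the 4 values shown sits.

Going by these compounds, it remains open whether bromo would read the same way on the core of compound 1, which keeps the hydrogen on that aromatic nitrogen. The compounds shown also leave open how fluoro, trifluoromethyl or an amine would read at this same place on the ring, and how a longer chain would read in place of the methyl on the nitrogen.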